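The compounds below may be only part of what the source reports. "The series", "measured", "known", "first", "only" and "open" are said of these compounds alone.

Measured so far in an ADME assay on MCF-10A cells (Homo sapiens) for inhibition, with a stated time of 48 h; a lower number here means a stronger inhibitor, a higher number a weaker inhibitor:
compound 1 `Cc1cccc(-c2noc([C@@H]3CCCN3C(=O)Nc3ccc(Cl)cc3)n2)c1`: > 50000 nM
compound 2 `N#Cc1cccc(-c2noc([C@@H]3CCCN3C(=O)Nc3ccc(Cl)cc3)n2)c1`: > 50000 nM

Compound 2 stands at > 50000 nM, which is a limit of the assay and not a number. The reading for compound 1, > 50000 nM, is likewise a limit. Together these give the whole picture so far: the limit of > 50000 nM in this assay, at which 2 of the 2 values shown sit.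

The next compound is compound 3 `Cc1ccc(-c2noc([C@@H]3CCCN3C(=O)Nc3ccc(Cl)cc3)n2)cc1`, with 4-methylphenyl in place of 3-cyanophenyl on an aromatic carbon of the five-membered ring: 4-methylphenyl in place of 3-cyanophenyl on an aromatic carbon.

Within the data shown here, the only measured step that bears on this change is a step that the two limits leave unreadable from compound 1 to compound 2, with cyano in place of methyl on an aromatic carbon. Its size cannot be read, so it offers no magnitude to carry over, and no direction can be argued from it. In this assay, no step beyond the scatter is expected, and another reading at the limit is the likeliest outcome. The expected result is a number no higher from compound 2 to compound 3 (the limit leaves the size open). Compound 3 is estimated at 50000 nM, with an expected range of 25000 nM to 100000 nM.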

Compound 3, half-maximal inhibitory concentration: > 50000 nM
Compound 3 ended at the assay's limit; the forecaster's own chance of this, stated with the estimate: 85%; the middle value sits exactly at the limit.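

Compound 3 reads > 50000 nM, a limit and not a number. No new step among compound 1, compound 2 and compound 3 can be read: the limit of > 50000 nM in this assay, at which 3 of the 3 values shown sit.

The compounds shown leave open whether any of these groups on the shared core moves inhibition at all, and in which direction or by how much.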